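A few compounds are considered here, and "the series" means these few. Any claim that something is new, unique, unknown or untested is made for them only; others in the source may bear on it.

Series read in a functional assay on A-375 cells (Homo sapiens) for activation, with a stated time of 3 days; on this read-out higher numbers stand for an effect only at larger amounts of compound and lower numbers for an effect already at smaller amounts:

Compound 1 `O=C(Nc1ccc(-c2cscn2)cc1)C1CCCN(C(=O)c2ccc(F)c(F)c2)C1`: > 20000 nM (a limit)
Compound 2 `O=C(Nc1ccc(-c2cscn2)cc1)C1CCCN(Cc2cccc(OC(F)(F)F)c2)C1`: > 20000 nM (a limit)
Compound 3 `O=C(Nc1ccc(-c2ccncc2)cc1)C1CCCN(Cc2ccc(F)c(F)c2)C1`: 1180 nM

For the measured compounds named here, compound 3, at 1180 nM, holds the only actual number. The other two readings are limits of the assay, so compound 3 can be ranked against them only by what those limits show.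

Next in line is compound 4 `O=C(Nc1ccc(-c2nccs2)cc1)C1CCCN(Cc2ccc(F)c(F)c2)C1`, which keeps everything in compound 3 except one group: 1,3-thiazol-2-yl in place of pyridin-4-yl on an aromatic carbon.

Going by the values given here, no measured pair isolates this change, so the expectation rests on indirect evidence. Compound 1 also has a five-membered aromatic ring on that aromatic carbon and differs from compound 3 elsewhere too. Compound 1 reads > 20000 nM, a limit. Compound 2 shares those two features and reads > 20000 nM, also a limit.

On that basis, a large step towards higher numbers in this assay, beyond the usual scatter, is expected, and a result at the limit would be no surprise. The expected step is a 6.8-fold higher number from compound 3 to compound 4 (0.83 log units; beyond the scatter). For compound 4 the estimated value is 8000 nM, with an expected range of 1500 nM to 20000 nM.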

Compound 4, half-maximal effective concentration: 800 nM
The estimate for compound 4 lay 10-fold (1.00 log units) above the measured number; the whole stated range lies above it.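

In this assay, the aromatic carbon para to a large group takes 1,3-thiazol-2-yl in place of pyridin-4-yl with a 1.5-fold lower number from compound 3 to compound 4 (0.17 log units; within the scatter). This is the only pair shown that differs in one place, and at this position the read-out does not separate the six-membered aromatic ring with 1 hetero atom from the five-membered aromatic ring with 2 hetero atoms. Compound 4 also adds a second actual number to the series, so a five-membered aromatic ring with 2 hetero atoms at this position does not by itself mean a reading at the limit: the limit of > 20000 nM in this assay, at which 2 of the 4 values shown sit.

On these data alone, compounds 1 and 2 each differ from compound 4 in more than one place, so steps to them cannot be read, and the change responsible for their limits stays open. Also open, as far as these compounds go, is how this position responds to a group of another kind, such as an amine, a carboxylic acid or a plain phenyl ring, since both groups read so far are nitrogen-containing aromatic rings.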